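Widening the amine ring on compound 3

A few compounds are considered here, and "the series" means these few. Any claim that something is new, unique, unknown or untested is made for them only; others in the source may bear on it.

Compound 3 `Cc1cc(=O)c2c(O)c(CN3CCCC3)c(O)c([C@H]3CCN(C)C[C@H]3O)c2o1` gives 12% in a functional assay on MCF7 cells (Homo sapiens) for inhibition, read by MTT assay, with a stated time of 48 h, tested at 10 uM (on this read-out higher numbers stand for more inhibition of growth at the one concentration tested and lower numbers for less inhibition of growth), the second highest of the three measured numbers. Its nearest neighbour is compound 2 `Cc1cc(=O)c2c(O)cc(OC/C=C/c3ccccc3)c([C@H]3CCN(C)C[C@H]3O)c2o1`, which gives 7%, a gap within the usual scatter; furthest away is compound 1 `Cc1cc(=O)c2c(O)cc(OCc3ccccc3Br)c([C@H]3CCN(C)C[C@H]3O)c2o1`, which gives 45%, a gap beyond the scatter. Among the compounds with values here, the only measured step, a number 38 percentage points lower from compound 1 to compound 2 (beyond the scatter), concerns a saturated chain carbon bound to an oxygen on an aromatic ring and leaves the (pyrrolidin-1-yl)methyl group untouched, so no measured step bears on the change to compound 4 `Cc1cc(=O)c2c(O)c(CN3CCCCC3)c(O)c([C@H]3CCN(C)C[C@H]3O)c2o1`: piperidin-1-yl in place of pyrrolidin-1-yl on a saturated chain carbon bound to an aromatic carbon. Without precedent, this change is expected to stay within the scatter. Compound 4 is therefore estimated at 15%, between 0% and 35%. This estimate means an expected step of a number 3 percentage points higher from compound 3 to compound 4 (within the scatter).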

Compound 4, percent growth inhibition at one concentration: 15%
For compound 4 middle estimate and measured number coincide at the digits printed; the measured number falls inside the stated range.
By their numbers in this assay, from the lowest: compounds 2, 3 and 4 (each within the scatter of the next); then compound 1.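

In this assay the one-carbon widening of the amine ring gives a number 3 percentage points higher from compound 3 to compound 4 (within the scatter), so at this saturated chain carbon bound to an aromatic carbon, the assay does not separate piperidin-1-yl from pyrrolidin-1-yl. Within the data shown here, this is the first measured step at this place, and it shows that ring size here, across these two rings, leaves the read-out unmoved beyond the scatter. No supporting measurement bears on this result. Still open, from the compounds shown here alone, is whether a morpholin-4-yl ring or an open-chain diethylamino group in the same place would give a step beyond the scatter.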